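Swapping Pentyl for Methoxy: An Expected Antiproliferative Value

A few compounds are considered here, and "the series" means these few. Any claim that something is new, unique, unknown or untested is made for them only; others in the source may bear on it.

Compound 1, `O=C1O/C(=C\Cn2cc(-c3ccc(Br)cc3)nn2)C(OCc2ccccc2)=C1OCc1ccccc1`: in a functional assay on CFPAC-1 cells (Homo sapiens) for antiproliferative activity, read by MTT assay, with a stated time of 72 h (a higher number here means a weaker inhibitor, a lower number a stronger inhibitor), compound 1 gives a limit, > 100000 nM.
Compound 2, `Cc1ccc(-c2cn(C/C=C3\OC(=O)C(OCc4ccccc4)=C3OCc3ccccc3)nn2)cc1`: in this assay compound 2 gives a limit, > 100000 nM.
Compound 3, `CCCCCc1ccc(-c2cn(C[C@H](O)[C@H]3OC(=O)C(OCc4ccccc4)=C3OCc3ccccc3)nn2)cc1`: in this assay compound 3 gives 9890 nM.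

Compound 3 is the only one of the three with a real number; the other two sit at a limit, (the limit of > 100000 nM in this assay, at which 2 of the 3 values shown sit). Compound 4, `COc1ccc(-c2cn(C[C@H](O)[C@H]3OC(=O)C(OCc4ccccc4)=C3OCc3ccccc3)nn2)cc1`, differs from compound 3 in one place: methoxy in place of pentyl on an aromatic carbon. For the measured compounds named here, the single measured step, a step that the two limits leave unreadable from compound 1 to compound 2, concerns a different change and cannot be read, so no measured step bears on this one. Without guidance, compound 4 is expected near compound 3 but with wide uncertainty, an estimated step of a 2.0-fold higher number from compound 3 to compound 4 (0.31 log units; beyond the scatter). Compound 4 is estimated at 20000 nM, between 5000 nM and 100000 nM.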

Compound 4, half-maximal inhibitory concentration: 26000 nM
For compound 4 the middle estimate is 1.3-fold (0.11 log units) below the measured one; the range from low to high includes it.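

In this assay, for the compounds shown here, methoxy in place of pentyl on the aromatic carbon gives a 2.6-fold higher number from compound 3 to compound 4 (0.42 log units; beyond the scatter), the first readable step; the earlier step, between two limits, cannot be read. Both compounds keep a real number, so the group at this position changes the reading only modestly. Nothing measured here explains the size of this step.

Going by these compounds alone, with only two groups compared at this position, no trend can be drawn. As far as these compounds go, how an amine, a carboxylic acid or a chain longer than pentyl would read there remains open.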